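Ester to oxadiazole swap on a cytotoxic pentyl-fused core

This account rests on a few compounds, and the source may have more. Where it says the series, first, only, none or still open, it means among the compounds named here.

Two compounds sharing a core carrying a cyclopentyl substituent were tested in a functional assay on MDA-MB-231 cells (Homo sapiens) for cytotoxicity, read by MTT assay, with a stated time of 24 h; on this read-out higher numbers stand for weaker inhibition and lower numbers for stronger inhibition. Compound 1, `Fc1cc(F)cc(C2Nc3cccnc3N2C2CCCC2)c1`, carries a difluorophenyl group and gives 2100 nM in this assay. Compound 2, `COC(=O)c1ccc(-c2nc3cccnc3n2C2CCCC2)cc1`, carries a methoxycarbonyl-substituted phenyl ring and gives 350 nM in this assay, the lowest of the two numbers; the nearest value, that of compound 1, stands well beyond the usual scatter above it.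

Compound 3, `Cc1nnc(-c2ccc(-c3nc4cccnc4n3C3CCCC3)cc2)o1`, is the unmeasured partner of compound 2. The change is 5-methyl-1,3,4-oxadiazol-2-yl in place of methoxycarbonyl on an aromatic carbon. The ester is replaced by a five-membered aromatic ring with three hetero atoms, a common exchange of one neutral acceptor-bearing group for another.

Among the measured compounds shown here, no measured pair illustrates this exchange, so the expectation for compound 3 rests on compound 2 alone. Compound 3 is expected to stay close to compound 2, with a step of a 1.1-fold higher number from compound 2 to compound 3 (0.06 log units; within the scatter), probably no larger than the scatter in either direction. The estimated value for compound 3 is 400 nM, with a range from 150 nM to 1200 nM.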

Compound 3, half-maximal inhibitory concentration: 21 nM
Estimate against measurement, compound 3: 19-fold (1.28 log units) above, outside the stated range (below it).
By their numbers in this assay, from the lowest: compound 3; then compound 2; then compound 1.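

In this assay, the place on the six-membered aromatic ring of carbon only, para to a large group, proves highly responsive to the group it carries: the exchange of methoxycarbonyl for 5-methyl-1,3,4-oxadiazol-2-yl gives a large change (a 17-fold lower number from compound 2 to compound 3 (1.22 log units; beyond the scatter)). Compound 2 alone could not show this, and the pair now shows that these two groups, both without net charge or hydrogen-bond donors, are far from interchangeable at this place in this cell assay. No measurement shown here accounts for the size of this step, and the reason for it remains unknown.

The compounds shown leave open whether the lower number belongs to the five-membered aromatic ring itself or depends on its methyl group, and how the same ring without that methyl, an amide, a nitrile or a carboxylic acid would compare at this place. They also leave open whether the exchange would have a similar effect in other cell lines or with a different substituent in place of the cyclopentyl group on the shared core.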